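The source may report more compounds than this note shows. Statements on the series, on what has been measured and on what is new or still open speak of the compounds shown alone.

Among the compounds with values here, compound 2 `O=C(CCCCl)Nc1ccc(S(=O)(=O)Oc2ccccc2I)cc1` gives 12000 nM in a functional assay on HT-1080 cells (Homo sapiens) for antiproliferative activity, read by sulforhodamine B assay, with a stated time of 48 h (a higher number here means a weaker inhibitor, a lower number a stronger inhibitor), the highest of the two numbers so far, with compound 1 `CCC(=O)Nc1ccc(S(=O)(=O)Oc2ccccc2I)cc1` nearest at 7200 nM. Within the data shown here, the one measured step, a 1.7-fold higher number from compound 1 to compound 2 (0.22 log units; within the scatter), lies within the scatter. Compound 3 `O=C(Nc1ccc(S(=O)(=O)Oc2ccccc2I)cc1)NC1CC1` differs from compound 2 by cyclopropylamino in place of 3-chloropropyl on a carbonyl carbon. Among the measured compounds shown here, no measured step touches this kind of change, and the single step to hand was small, so for compound 3 the number in this assay is expected near that of compound 2, with an estimated step of a 1.2-fold lower number from compound 2 to compound 3 (0.08 log units; within the scatter). Compound 3 is therefore estimated at 10000 nM, between 3000 nM and 40000 nM.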

Compound 3, half-maximal inhibitory concentration: 1300 nM
The estimate for compound 3 lay 7.7-fold (0.89 log units) above the measured number; the whole stated range lies above it.
By their numbers in this assay, from the lowest: compound 3; then compounds 1 and 2 (each within the scatter of the next).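

In this assay the group on this carbonyl carbon proves to matter: cyclopropylamino in place of 3-chloropropyl gives a 9.2-fold lower number from compound 2 to compound 3 (0.97 log units; beyond the scatter) and cyclopropylamino in place of ethyl gives a 5.5-fold lower number from compound 1 to compound 3 (0.74 log units; beyond the scatter) while the earlier change within the chain stayed within the scatter. The entering group brings both a three-membered ring and a hydrogen-bond donor, and these steps do not separate the two. No evidence at hand accounts for the result.

An ethylamino or a cyclopropyl group on this carbonyl carbon would tell the nitrogen's share from the ring's. From the compounds shown here alone, how a larger ring, such as cyclohexylamino, would fare remains open.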